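Replacing 4-hydroxyphenyl with 3-fluorophenyl: exposure notes

The compounds below may be only part of what the source reports. "The series", "measured", "known", "first", "only" and "open" are said of these compounds alone.

Values measured in an ADME assay on the whole organism (Mus musculus, strain Swiss Webster) for pharmacokinetics, read by LC-MS, at a dose of 50 mg/kg by the oral route (on this read-out higher numbers stand for higher exposure at the dose given and lower numbers for lower exposure), are as follows.
- Compound 1 `O=C(Nc1ccc(F)c(-c2nc3ncc(-c4ccc(F)cc4)cc3[nH]2)c1)N1CCCC1` gives 10200 ng.h/mL in this series
- Compound 2 `O=C(Nc1ccc(F)c(-c2nc3ncc(C(F)(F)F)cc3[nH]2)c1)N1CCCC1` gives 489 ng.h/mL in this series
- Compound 3 `O=C(Nc1ccc(F)c(-c2nc3ncc(-c4ccc(O)cc4)cc3[nH]2)c1)N1CCCC1` gives 137 ng.h/mL in this series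

Compound 3 stands lowest of the three numbers. The next change leads to compound 4 `O=C(Nc1ccc(F)c(-c2nc3ncc(-c4cccc(F)c4)cc3[nH]2)c1)N1CCCC1` and places 3-fluorophenyl in place of 4-hydroxyphenyl on an aromatic carbon on the shared core. Among the measured compounds shown here, no measured compound carries 3-fluorophenyl, so the evidence is indirect. The closest measured step is a 74-fold lower number from compound 1 to compound 3 (1.87 log units; beyond the scatter) in the same read-out. It is large and beyond the scatter, and it is hydroxy in place of fluoro on an aromatic carbon, roughly the reverse of the present change. The step of a 21-fold lower number from compound 1 to compound 2 (1.32 log units; beyond the scatter) is also large, while a 3.6-fold lower number from compound 2 to compound 3 (0.55 log units; beyond the scatter) is modest. Thus the one fluorophenyl compound, compound 1 at 10200 ng.h/mL in this assay, stands far above both others. A large upward step is therefore expected, though the fluoro group sits elsewhere on the ring than in compound 1, so full recovery of that number is not assumed. The estimated step is a 36-fold higher number from compound 3 to compound 4 (1.56 log units; beyond the scatter) in this read-out. For compound 4 the expected value is 5000 ng.h/mL, with an estimated range from 1200 ng.h/mL to 15000 ng.h/mL in this assay.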

Compound 4, area under the concentration-time curve: 15000 ng.h/mL
For compound 4 the middle estimate is 3.0-fold (0.48 log units) below the measured one, within the range that was stated.
By their numbers in this assay, from the lowest: compound 3; then compound 2; then compounds 1 and 4 (each within the scatter of the next).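

In this assay the high exposure is not tied to 4-fluorophenyl alone: 3-fluorophenyl on the same aromatic carbon gives a number that cannot be told apart from that of compound 1 (a 1.5-fold higher number from compound 1 to compound 4 (0.17 log units; within the scatter)). An aryl group at this position does not by itself carry the effect, as the large gain over trifluoromethyl (a 31-fold higher number from compound 2 to compound 4 (1.49 log units; beyond the scatter)) holds for 3-fluorophenyl, while compound 3, with 4-hydroxyphenyl, stays the lowest of the series. The exchange of 4-hydroxyphenyl for 3-fluorophenyl (a 110-fold higher number from compound 3 to compound 4 (2.04 log units; beyond the scatter)) is the largest step seen here, yet it replaces hydroxy with fluoro and shifts the substituent on the ring in one change, so the two contributions cannot be separated.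

Still open, going by these compounds, is whether fluoro is needed at all or whether removing the hydroxy is enough: an unsubstituted phenyl, or a methoxy or an amine on the same ring, would bear on that. No evidence at hand accounts for these differences in exposure.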